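Oxadiazole for Carbamoyl on Two Cores: Tolerated Concentration

The source may report more compounds than this note shows. Statements on the series, on what has been measured and on what is new or still open speak of the compounds shown alone.

Compound 1 `CC(C)[C@H]1C(O)=C(C2=NS(=O)(=O)c3c(OCC(N)=O)cccc32)C(=O)N1Cc1ccccc1` carries a carbamoyl group on a saturated chain carbon bound to an oxygen on an aromatic ring. In an ADME assay on Huh-7 cells (Homo sapiens) for cytotoxicity, with a stated time of 72 h (a higher number here means that more compound is tolerated, a lower number that less compound is tolerated), compound 1 is reported only as a limit of the assay, > 33000 nM. Compound 2 `CC(C)[C@H]1C(O)=C(C2=NS(=O)(=O)c3c(OCc4ncon4)cccc32)C(=O)N1Cc1ccccc1` differs from it by 1,2,4-oxadiazol-3-yl in place of carbamoyl on a saturated chain carbon bound to an oxygen on an aromatic ring. In this assay compound 2 is likewise reported as a limit, > 33000 nM. The step that the two limits leave unreadable from compound 1 to compound 2 therefore cannot be read, as both values are limits; all three measured compounds sit at the limit of > 33000 nM in this assay, at which 3 of the 3 values shown sit.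

Compound 3 `CC(C)(C)CCN1C(=O)C(C2=NS(=O)(=O)c3c(OCC(N)=O)cccc32)=C(O)[C@@H]1C(C)(C)C` is built on another core; the difference between the two cores is not broken down here. In this assay compound 3 is again reported only as a limit, > 33000 nM. Compound 4 `CC(C)(C)CCN1C(=O)C(C2=NS(=O)(=O)c3c(OCc4ncon4)cccc32)=C(O)[C@@H]1C(C)(C)C` differs from compound 3 by 1,2,4-oxadiazol-3-yl in place of carbamoyl on a saturated chain carbon bound to an oxygen on an aromatic ring, the same change at the same place as between the first two compounds. Because every value rests at the limit of > 33000 nM in this assay, at which 3 of the 3 values shown sit, and the earlier step is unreadable, the expected step of a number no higher from compound 3 to compound 4 (the limit leaves the size open) is close to nothing. Compound 4 is expected to give about 33000 nM, most likely again as a limit.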

Compound 4, half-maximal cytotoxic concentration: > 33000 nM
Compound 4: only a limit was reported; the forecaster's own chance of this, stated with the estimate: 85%; the middle value lies on the limit itself.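

In this assay, compound 3 and compound 4 are each reported only as a limit, so no step between them can be read: the limit of > 33000 nM in this assay, at which 4 of the 4 values shown sit.

The compounds shown leave open whether 1,2,4-oxadiazol-3-yl in place of carbamoyl changes the tolerated concentration at all, on either core, in this assay.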